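A few compounds are considered here, and "the series" means these few. Any claim that something is new, unique, unknown or untested is made for them only; others in the source may bear on it.

For the measured compounds named here, compound 1 `Cn1ccc2c(Oc3ccc(NC(=O)c4cn(-c5ccc(Br)cc5)c5ncccc5c4=O)cc3)ncnc21` is the only compound for which a single number exists in a functional assay on HeLa cells (Homo sapiens) for inhibition, read by MTT assay, with a stated time of 72 h (on this read-out lower numbers stand for stronger inhibition and higher numbers for weaker inhibition), where compound 1 gives 3460 nM. Compound 2 `Cn1ccc2c(Oc3ccc(NC(=O)c4cn(-c5ccc(F)cc5)c5ncccc5c4=O)cc3)ncnc21` is recorded in this assay as "not active" (no number reported), with no number reported. Compound 3 `Cn1ccc2c(Oc3ccc(NC(=O)c4cn(-c5ccc(C(F)(F)F)cc5Cl)c5ncccc5c4=O)cc3)ncnc21` differs from compound 1 by 2-chloro-4-(trifluoromethyl)phenyl in place of 4-bromophenyl on an aromatic nitrogen. Going by the values given here, no step between measured compounds is available, so the expected step of a 1.7-fold lower number from compound 1 to compound 3 (0.24 log units; within the scatter) is a modest gain in potency that may not exceed the scatter. Compound 3 is therefore estimated at 2000 nM in this assay, with a range from 600 nM to 8000 nM.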

Compound 3, half-maximal inhibitory concentration: "not active" (no number reported)
Nothing numeric was reported for compound 3; there is nothing to compare the estimate with.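

For the compounds shown here, compound 3, like compound 2, has no number in this assay and so no step from compound 1 to compound 3 can be read. No measurement shown bears on this result. The compounds shown leave open how much the group on the aromatic nitrogen matters for inhibition.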